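Adding a Trifluoromethyl Group to a Weak Kinase Inhibitor

The source may hold more compounds than are shown below. What is called first, only, known or untested is meant among the compounds shown, and "the series" means these compounds.

compound 1 `CCC(=O)N1CC[C@H](Oc2ncnc3c2CN(c2ccc(OC)nc2)CC3)C1`: 8940 nM
compound 2 `COc1ccc(N2CCc3ncnc(-c4cccc(OC5CCN(C(C)=O)CC5)c4)c3C2)cn1`: > 9100 nM
compound 3 `COc1ccc(N2CCc3ncnc(-c4cccc(C(=O)N5CCN(C(C)=O)CC5)c4)c3C2)cn1`: > 9100 nM

Of the compounds shown here, three have been measured in an ADME assay on isolated protein for inhibition of phosphatidylinositol 4,5-bisphosphate 3-kinase catalytic subunit beta isoform (Homo sapiens), read by Kinase-Glo, with a stated time of 60 min; on this read-out lower numbers stand for stronger inhibition and higher numbers for weaker inhibition. For the measured compounds named here, compound 1 is the only one that gives a number, 8940 nM. Compound 2 stops at a limit of the assay, > 9100 nM. Compound 3 also stops at a limit, > 9100 nM. Going by the values given here, the single step between measured compounds that differ in one place, a step that the two limits leave unreadable from compound 2 to compound 3, cannot be read in size because both of its values sit at the limit of > 9100 nM in this assay, at which 2 of the 3 values shown sit. Compound 1 thus stands alone as the one fixed point, and it is weak.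

The unmeasured compound 4 `CCC(=O)N1CC[C@H](Oc2ncnc3c2CN(c2cnc(OC)c(C(F)(F)F)c2)CC3)C1` differs from compound 1 by trifluoromethyl in place of hydrogen on an aromatic carbon. Among the compounds with values here, no measured step involves this change, so there is nothing to suggest a shift beyond the usual scatter in either direction. Compound 4 is therefore expected to give about 8000 nM, within a range of 2500 nM to 25000 nM. The expected step of a 1.1-fold lower number from compound 1 to compound 4 (0.05 log units; within the scatter) is estimated to stay within the scatter.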

Compound 4, half-maximal inhibitory concentration in the phosphatidylinositol 4,5-bisphosphate 3-kinase catalytic subunit beta isoform assay: 1710 nM
For compound 4 the middle estimate is 4.7-fold (0.67 log units) above the measured one; measured number below the stated range.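

For the compounds shown here, in the phosphatidylinositol 4,5-bisphosphate 3-kinase catalytic subunit beta isoform assay, trifluoromethyl in place of hydrogen on an aromatic carbon, ortho to a methoxy group, gives a 5.2-fold lower number from compound 1 to compound 4 (0.72 log units; beyond the scatter), so this place on the ring, which no earlier step touched, can shift the read-out. In a physicochemical assay for solubility, read by LC-MS, measured as thermodynamic solubility, at pH 6.8 (on this read-out higher numbers stand for higher solubility and lower numbers for lower solubility), compound 1 gives > 1000000 nM, which is a limit of the assay. In the physicochemical assay compound 4 gives 80000 nM, so the same change that improves inhibition also comes with lower solubility: the measured solubility of compound 1, > 1000000 nM, and of compound 4, 80000 nM, an at least 12-fold lower number (1.09 log units; beyond the scatter)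

From the compounds shown here alone, whether a smaller group at this place, such as a methyl group or a chlorine atom, would give the same gain in inhibition with less loss of solubility stays open. The step between compound 2 and compound 3 cannot be read, and whether trifluoromethyl would help those two compounds is also unknown.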